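Carbamoyl for phenyl on a ring nitrogen: inhibition notes

The source may report more compounds than this note shows. Statements on the series, on what has been measured and on what is new or still open speak of the compounds shown alone.

Measured so far:
compound 1 `CC1(C)CC(=O)C2=C(C1)N(c1ccccc1)N=C(c1ccccc1)C2` — "not active" (no number reported)
compound 2 `CC1(C)CC(=O)C(CC(=O)c2ccccc2)=C(NNC(=N)N)C1` — 1%

In a functional assay on the whole organism (Central nervous system, strain CF) for inhibition, with Mus musculus as the target, with a stated time of 15 min, at a dose of 500 mg/kg by the oral route (on this read-out higher numbers stand for more inhibition at the one dose given (going by the name of the read-out) and lower numbers for less inhibition), compound 1 gives "not active" (no number reported), so no number places it; compound 2 gives 1% in this assay. Both measured compounds sit at the floor of the read-out. Compound 3 `CC1(C)CC(=O)C2=C(C1)N(C(N)=O)N=C(c1ccccc1)C2` differs from compound 1 by carbamoyl in place of phenyl on an amine nitrogen in a ring: phenyl leaves and carbamoyl enters, bringing one hydrogen-bond donor and one hydrogen-bond acceptor. Within the data shown here, with no step between measured compounds to draw on, the expected step from compound 1 to compound 3 in this assay is none beyond the scatter. Compound 3 is expected to give about 5%, between 0% and 25%.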

Compound 3, a percentage reported as inhibition, in the whole organism at one dose (the size of the read-out at that dose, not a potency): "not active" (no number reported)
Compound 3 has no reported number here; there is nothing to compare the estimate with.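

Compound 1 and compound 3 carry no number in this assay, so no step can be read between them. On these data alone, whether carbamoyl in place of phenyl on an amine nitrogen in a ring changes inhibition stays open. No measured evidence bears on this result.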